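Hydroxy in place of dimethylamino: cytotoxicity working notes

The source may hold more compounds than are shown below. What is called first, only, known or untested is meant among the compounds shown, and "the series" means these compounds.

Among the measured compounds shown here, compound 3 `CCOC(=O)CCCCCOc1cccc(CN(C(=O)c2ccc(-c3cccc(N(C)C)c3)cc2)C(C)C)c1` is one of three compounds measured in an ADME assay on HEK293 cells (Homo sapiens) for cytotoxicity, read by CellTiter-Glo and resazurin assay, with a stated time of 72 h; a lower number here means that less compound is needed, a higher number that more compound is needed for the effect. For compound 3 the assay reports only a limit, > 26000 nM. Compound 1 `CC(C)N(Cc1cccc(OCCCCCC(=O)O)c1)C(=O)c1ccc(-c2cccc(N(C)C)c2)cc1` likewise gives only a limit, > 26000 nM. Compound 2 `CC(C)N(Cc1cccc(OCCCCCC(=O)O)c1)C(=O)c1ccc(-c2cccc(Oc3ccccc3)c2)cc1` also gives a limit, > 18700 nM. Two of the three values thus sit at the limit of > 26000 nM in this assay, at which 2 of the 3 values shown sit, and one at the limit of > 18700 nM in this assay, at which 1 of the 3 values shown sits. The step from compound 1 to compound 2, a step that the two limits leave unreadable from compound 1 to compound 2, and the step from compound 1 to compound 3, a step that the two limits leave unreadable from compound 1 to compound 3, cannot be read for size, since both ends of each are limits.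

Compound 4 `CCOC(=O)CCCCCOc1cccc(CN(C(=O)c2ccc(-c3cccc(O)c3)cc2)C(C)C)c1` differs from compound 3 in one place: hydroxy in place of dimethylamino on an aromatic carbon. For the measured compounds named here, none of the measured steps covers this change, and none of them has a readable size in this assay, so no direction or size of step can be drawn from them. Going by the values given here, with every value so far a limit, compound 4 is expected to give a limit as well. The estimate for compound 4 is 30000 nM, with a range from 15000 nM to 60000 nM. On that estimate the expected step is a step that the limit leaves unreadable from compound 3 to compound 4, none beyond the scatter.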

Compound 4, half-maximal effective concentration: > 26000 nM
Compound 4 ended at the assay's limit; the forecaster's own chance of this, stated with the estimate: 80%; the middle value is on the limit's open side.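

Compound 3 and compound 4 both stand only as limits in this assay; no step can be read between them for hydroxy in place of dimethylamino. The compounds shown leave open the actual half-maximal effective concentration of all four compounds, and whether this change alters it.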